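The source may report more compounds than this note shows. Statements on the series, on what has been measured and on what is new or still open speak of the compounds shown alone.

Measured compounds:
Compound 1, `Cn1cncc1C(OCc1ccc(C#N)c(-c2ccc(Cl)c(Cl)c2)n1)c1ccc(C#N)cc1`, in an assay on isolated protein (Bos taurus) for inhibition of geranylgeranyl transferase type-1 subunit beta (Homo sapiens) (a higher number here means a weaker inhibitor, a lower number a stronger inhibitor), gives 1600 nM.
Compound 2, `Cn1cncc1C(OCc1ccc(C#N)nc1-c1cc(Cl)cc(Cl)c1)c1ccc(C#N)cc1`, in this assay gives 1400 nM.
Compound 3, `Cn1cncc1C(OCc1ccc(C#N)c(-c2ccc(Cl)cc2)n1)c1ccc(C#N)cc1`, in this assay gives 3900 nM.

Compound 2 has the same atoms as compound 1, joined differently; the difference between the two cores is not broken down here. The values of compound 1 and compound 2 lie within the usual scatter of each other, while compound 3 lies beyond the scatter from compound 2, with the higher number. Compound 3 differs from compound 1 by hydrogen in place of chloro on an aromatic carbon; that step reads a 2.4-fold higher number from compound 1 to compound 3 (0.39 log units; beyond the scatter). Compound 4, `Cn1cncc1C(OCc1ccc(C#N)nc1-c1cccc(Cl)c1)c1ccc(C#N)cc1`, is not yet measured; it differs from compound 2 by hydrogen in place of chloro on an aromatic carbon. This is the same kind of change, not the same: in compound 1 the carbon that loses its chloro is ortho to a chloro group, in compound 2 it is meta to a chloro group. Among the compounds with values here, compound 4 is expected to show a step of a 2.3-fold higher number from compound 2 to compound 4 (0.36 log units; beyond the scatter) in this assay, about as large as the earlier one, because the single earlier instance of this kind of change gave a 2.4-fold higher number from compound 1 to compound 3 (0.39 log units; beyond the scatter). The estimate for compound 4 in this assay is 3200 nM, with a range from 1600 nM to 6500 nM.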

Compound 4, half-maximal inhibitory concentration: 1700 nM
Beside the measured number, compound 4's estimate is 1.9-fold (0.27 log units) above it, and the stated range covers the measured number.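

Hydrogen in place of chloro, 3,5-dichlorophenyl to 3-chlorophenyl, reads in this assay as a 1.2-fold higher number from compound 2 to compound 4 (0.08 log units; within the scatter). Set beside the step on the other core, the two do not separate: the same change on two cores in this assay, a 2.4-fold higher number (0.39 log units; beyond the scatter) from compound 1 to compound 3 and a 1.2-fold higher number (0.08 log units; within the scatter) from compound 2 to compound 4, 2.0-fold (0.30 log units) apart, within the scatter of two such steps The change can therefore be carried between these two cores as far as the numbers can tell, but with one step beyond the scatter and one within it, two instances neither fix a common size for the step nor show that the cores respond alike or differently.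

The compounds shown leave open what happens when the last chloro gives way to hydrogen on the core of compound 4, and whether a chloro-to-hydrogen step would read the same in any other chlorine pattern on these cores. They also leave open how other groups would behave in that place, such as methoxy, trifluoromethyl or an amine.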